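A few compounds are considered here, and "the series" means these few. Any claim that something is new, unique, unknown or untested is made for them only; others in the source may bear on it.

Measured compounds:
- compound 1, `O=c1oc2ccccc2cc1C1=NN(c2ccccc2)[C@@H](c2ccccc2)C1`: 27.2%
- compound 2, `O=c1oc2ccccc2cc1C1=NN(c2ccccc2)[C@@H](c2ccc(Cl)cc2)C1`: 39.2%
- compound 3, `CN(C)c1ccc([C@H]2CC(c3cc4ccccc4oc3=O)=NN2c2ccccc2)cc1`: 28.4%

In a functional assay on the whole organism (strain albino) for inhibition, with Rattus norvegicus as the target, read by paw edema, with stated times of 1 h and 2 h, at a dose of 200 mg/kg by the oral route (on this read-out higher numbers stand for more inhibition at the one dose given (going by the name of the read-out) and lower numbers for less inhibition), compound 3 stands second highest of the three numbers. Its nearest neighbour is compound 1, since a number 1.2 percentage points higher from compound 1 to compound 3 (within the scatter); its furthest is compound 2, since a number 10.8 percentage points lower from compound 2 to compound 3 (beyond the scatter). Compound 4, `Cc1ccc([C@H]2CC(c3cc4ccccc4oc3=O)=NN2c2ccccc2)cc1`, has not been measured. It differs from compound 3 in one place: methyl in place of dimethylamino on an aromatic carbon.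

For the measured compounds named here, no measured step puts a methyl on this aromatic carbon, so the bearing steps are indirect. Swapping hydrogen for dimethylamino gave a number 1.2 percentage points higher from compound 1 to compound 3 (within the scatter), a change within the scatter, while the chloro compound sits higher, as a number 10.8 percentage points lower from compound 2 to compound 3 (beyond the scatter) shows. Two of the three substituents at this carbon therefore leave the number close to that of the unsubstituted compound 1, and only chloro moves it by a modest amount. Compound 4 is expected to sit near compound 3, with a step of a number 2.6 percentage points higher from compound 3 to compound 4 (within the scatter) that is not expected to exceed the scatter. Compound 4 is thus estimated at 31%, within 22% to 42%.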

Compound 4, a percentage reported as inhibition, in the whole organism at one dose (the size of the read-out at that dose, not a potency): 30.1%
Beside the measured number, compound 4's estimate is 0.9 percentage points above it; the measured number falls inside the stated range.
By their numbers in this assay, from the lowest: compounds 1, 3, 4 and 2 (each within the scatter of the next, the first and the last beyond it).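

In this assay, methyl in place of dimethylamino gives a number 1.7 percentage points higher from compound 3 to compound 4 (within the scatter) and methyl in place of hydrogen gives a number 2.9 percentage points higher from compound 1 to compound 4 (within the scatter), so on this aromatic carbon, para to a large group, methyl cannot be told apart from either. Methyl in place of chloro gives a number 9.1 percentage points lower from compound 2 to compound 4 (within the scatter), so compound 4 cannot be told apart from compound 2 either, although compound 1 and compound 3 each lie beyond the scatter from compound 2. Methyl therefore bridges the one gap seen earlier at this position, and chloro no longer stands apart from every other group there.

As far as these compounds go, whether a methoxy group, a carboxylic acid or a longer chain on this carbon would move the number clearly out of this band stays open. Nothing available explains why these groups give these numbers.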